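The source may hold more compounds than are shown below. What is called first, only, known or untested is meant among the compounds shown, and "the series" means these compounds.

In an ADME assay on the whole organism for pharmacokinetics, with Mus musculus as the target, at a dose of 10 mg/kg by the oral route (on this read-out lower numbers stand for lower exposure and higher numbers for higher exposure at the dose given), compound 1 `CC/C(=C(/c1ccc(/C=C/C(=O)O)cc1)c1ccc2[nH]ncc2c1)c1ccccc1Cl` gives 15000 ng.h/mL and compound 2 `CC/C(=C(/c1ccc(/C=C/C(=O)O)cc1)c1ccc2[nH]ncc2c1)c1cccc(Cl)c1` gives 11000 ng.h/mL while compound 3 `CC/C(=C(/c1ccc(/C=C/C(=O)O)cc1)c1ccc2[nH]ncc2c1)c1ccc(C#N)cc1C` stands lowest of the three at 4300 ng.h/mL on these numbers. Compound 4 `CC/C(=C(/c1ccc(/C=C/C(=O)O)cc1)c1ccc2[nH]ncc2c1)c1cscc1C` carries 4-methylthiophen-3-yl in place of 4-cyano-2-methylphenyl on a double-bonded chain carbon, a change counted as 4-methylthiophen-3-yl in place of 4-cyano-2-methylphenyl on a double-bonded chain carbon bound to a double-bonded chain carbon and a saturated chain carbon here. Going by the values given here, earlier swaps at this place offer the only guide. The step of a 1.4-fold lower number from compound 1 to compound 2 (0.13 log units; within the scatter) stayed within the scatter, whereas a 3.5-fold lower number from compound 1 to compound 3 (0.54 log units; beyond the scatter) and a 2.6-fold lower number from compound 2 to compound 3 (0.41 log units; beyond the scatter) were modest, both ending at 4-cyano-2-methylphenyl. Among the compounds with values here, no measured compound carries 4-methylthiophen-3-yl, so the guide is loose. A modest rise is expected, an estimated 2.1-fold higher number from compound 3 to compound 4 (0.32 log units; beyond the scatter) in this assay terms. The estimated value for compound 4 is 9000 ng.h/mL with 3500 ng.h/mL to 23000 ng.h/mL as its expected range.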

Compound 4, area under the concentration-time curve: 3800 ng.h/mL
Compound 4: middle estimate off by 2.4-fold (0.37 log units), on the high side, within the range that was stated.
By their numbers in this assay, from the lowest: compounds 4 and 3 (each within the scatter of the next); then compounds 2 and 1 (each within the scatter of the next).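

In this assay the change to the smaller five-membered ring gives a 1.1-fold lower number from compound 3 to compound 4 (0.05 log units; within the scatter) and so leaves exposure within the scatter, which shows that the nitrile is not required for a number this low. Both chlorophenyl compounds stay clearly apart, with a 2.9-fold lower number from compound 2 to compound 4 (0.46 log units; beyond the scatter) and a 3.9-fold lower number from compound 1 to compound 4 (0.60 log units; beyond the scatter) as the steps. Nothing measured here explains these differences. As far as these compounds go, compound 3 and compound 4 both carry a methyl group, but whether it goes with their lower numbers remains open. A methoxy group or an amine at this place could help to test that.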